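The source may hold more compounds than are shown below. What is called first, only, known or untested is meant among the compounds shown, and "the series" means these compounds.

Working notes on the series. In an assay on isolated protein for inhibition of Fatty-acid amide hydrolase 1 (Homo sapiens) (on this read-out lower numbers stand for stronger inhibition and higher numbers for weaker inhibition), compound 1 `CCCCCCCC/C=C\CCCCCCC(=O)c1nc2cnccc2o1` gives 7.2 nM, the second highest of the three numbers measured. Its nearest neighbour, compound 2 `O=C(CCCCc1ccccc1)c1nc2ncccc2o1`, gives 0.3 nM in this assay, a lower number well beyond the scatter; compound 3 `CCCCCCCCCCCCCCCCCC(=O)C(F)(F)F`, the furthest, gives 240 nM, higher again beyond the scatter. Within the data shown here, no step between compounds differing in one place has been measured, so what follows rests on the structural change alone. Compound 4 `CCCCCCCC/C=C\CCCCCCC(=O)c1ccncn1` differs from compound 1 by a group of 6 heavy atoms (4 carbon, 2 nitrogen; one six-membered aromatic ring with 2 hetero atoms) in place of a group of 9 heavy atoms (6 carbon, 2 nitrogen, 1 oxygen; one five-membered aromatic ring with 2 hetero atoms, one six-membered aromatic ring with 1 hetero atom), on a carbonyl carbon. The expected step in this assay, from compound 1 to compound 4, is a moderate rise in the number, a 5.6-fold higher number from compound 1 to compound 4 (0.74 log units; beyond the scatter), beyond the scatter. Compound 4 is therefore estimated at 40 nM in this assay, within a range of 8 nM to 250 nM.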

Compound 4, inhibition constant: 110 nM
Estimate against measurement, compound 4: 2.8-fold (0.44 log units) below; low and high end bracket the measured number.
By their numbers in this assay, from the lowest: compound 2; then compound 1; then compound 4; then compound 3.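

With the chain held constant, the group on the carbonyl carbon alone sets a large part of the number in this assay: pyrimidin-4-yl in place of the group of compound 1 gives a 15-fold higher number from compound 1 to compound 4 (1.18 log units; beyond the scatter). This position is therefore sensitive to the change, and the single aromatic ring does not stand in for the two rings it replaces. Nothing at hand accounts for the size of this step.

Which part of the group that leaves matters stays open. So does the outcome with a nitrile or an oxazole bearing a carboxylic acid on the same carbonyl carbon.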